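The source may report more compounds than this note shows. Statements on the series, on what has been measured and on what is new or still open speak of the compounds shown alone.

Compound 2 `O=C1Nc2ccc(C(=O)c3ccco3)cc2/C1=C/c1cc(I)c(O)c(I)c1` stands lowest of the two compounds measured in an assay on HeLa cells for inhibition of Kinesin-like protein KIF15 (Homo sapiens), read by microscopy, with stated times of 2 s and 20 s, tested at 750 nM; a lower number here means less inhibition, a higher number more inhibition at the concentration tested (going by the name of the read-out): compound 2 gives 26%, while the nearest, compound 1 `O=C1Nc2ccc(C(=O)c3ccco3)cc2/C1=C/c1cc(Br)c(O)c(Br)c1`, gives 65%. For the measured compounds named here, the one step between them, a number 39 percentage points lower from compound 1 to compound 2 (beyond the scatter), is a large fall. Compound 3 `O=C1Nc2ccc(C(=O)c3ccco3)cc2/C1=C/c1cc(Cl)c(O)c(Br)c1` carries a group of 9 heavy atoms (6 carbon, 1 oxygen, 1 chlorine, 1 bromine; one six-membered aromatic ring of carbon only) in place of a group of 9 heavy atoms (6 carbon, 1 oxygen, 2 iodine; one six-membered aromatic ring of carbon only), on a double-bonded chain carbon bound to a double-bonded ring carbon. Because a number 39 percentage points lower from compound 1 to compound 2 (beyond the scatter) followed the exchange of two bromines for two iodines, and the new group restores one bromine and adds a chlorine, an upward step is expected for compound 3, a number 29 percentage points higher from compound 2 to compound 3 (beyond the scatter), recovering much of that fall. Compound 3 is therefore estimated at 55%, within 30% to 75%.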

Compound 3, a percentage reported as inhibition, at one concentration (the size of the read-out at that concentration, not a potency): 62%
Beside the measured number, compound 3's estimate is 7 percentage points below it, and the stated range covers the measured number.
By their numbers in this assay, from the lowest: compound 2; then compounds 3 and 1 (each within the scatter of the next).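

In this assay there is a number 36 percentage points higher from compound 2 to compound 3 (beyond the scatter) when the 4-hydroxy-3,5-diiodophenyl group leaves, so among these compounds the low value of compound 2 goes with the two iodines, not with halogen at this place in general. Chloro in place of bromo on an aromatic carbon gives a number 3 percentage points lower from compound 1 to compound 3 (within the scatter) and so does not separate the two compounds in this read-out. Nothing available explains either step.

Still open, from the compounds shown here alone, is how a ring carrying two chlorines would read at this place. Also open, going by these compounds, is whether a methoxy group or an amine could stand in for the hydroxyl.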